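Working notes on microsomal half-life in the series

A few compounds are considered here, and "the series" means these few. Any claim that something is new, unique, unknown or untested is made for them only; others in the source may bear on it.

Within the data shown here, compound 2 `Nc1ncnc2c1c(Oc1cc(C(F)(F)F)ccn1)nn2[C@@H]1CCCC[C@H]1O` holds the higher of the two numbers measured so far: in an ADME assay on microsomes from liver (Mus musculus) for metabolic stability, read by LC-MS, using NADPH, with a stated time of 10 min, tested at 10 uM (a lower number here means that the compound disappears faster, a higher number that the compound lasts longer), compound 2 gives 1.1 h, whereas compound 1 `N#Cc1ccnc(Oc2nn(C3CCC3)c3ncnc(N)c23)c1` gives 0.4 h, a gap beyond the scatter. Compound 3 `Nc1ncnc2c1c(Oc1cc(C(F)(F)F)ccn1)nn2[C@H]1CC[C@@H](N)CC1` is not yet measured and differs from compound 2 by 4-aminocyclohexyl in place of 2-hydroxycyclohexyl on an aromatic nitrogen. Among the measured compounds shown here, no measured pair shows this change, so its size is unknown from the data. The step expected in this assay is a 1.1-fold lower number from compound 2 to compound 3 (0.04 log units; within the scatter), judged not to go beyond the scatter. For compound 3 the estimated half-life in this assay is 1 h, with a range from 0.4 h to 2.5 h.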

Compound 3, half-life: 0.917 h
The estimate for compound 3 lay 1.1-fold (0.04 log units) above the measured number; the measured number falls inside the stated range.
By their numbers in this assay, from the lowest: compound 1; then compounds 3 and 2 (each within the scatter of the next).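

Among these compounds, the only readable step at this position is 4-aminocyclohexyl in place of 2-hydroxycyclohexyl on an aromatic nitrogen, and in this assay it gives a 1.2-fold lower number from compound 2 to compound 3 (0.08 log units; within the scatter). With the rest of the structure unchanged, this exchange leaves the half-life within the scatter. Nothing available explains this result.

The step exchanges both the ring substituent and where it sits on the cyclohexyl ring, and the two changes cannot be told apart. A 4-hydroxycyclohexyl or a 2-aminocyclohexyl group would separate them, and a carboxylic acid on the ring remains an open case.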